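Swapping one ring on compound 1: a cytotoxicity estimate

The source may report more compounds than this note shows. Statements on the series, on what has been measured and on what is new or still open speak of the compounds shown alone.

- compound 1 `Cc1cc(Oc2cccc(Cn3cncn3)c2)cc(C)c1Cl`: 75900 nM
- compound 2 `Cc1cc(Oc2cccc(Cn3cc4ccccc4n3)c2)cc(C)c1Cl`: > 100000 nM

For the measured compounds named here, in an ADME assay on NIH3T3 cells (Mus musculus) for cytotoxicity (a higher number here means that more compound is needed for the effect, a lower number that less compound is needed), compound 1 gives 75900 nM, the only actual number so far. Compound 2 gives > 100000 nM, which is a limit of the assay and not a number. One thing to keep in view is the limit of > 100000 nM in this assay, at which 1 of the 2 values shown sits.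

The next compound to be tested is compound 3 `Cc1nnc(Cc2cccc(Oc3cc(C)c(Cl)c(C)c3)c2)o1`. It keeps the core of compound 1 and changes one group: 5-methyl-1,3,4-oxadiazol-2-yl in place of 1H-1,2,4-triazol-1-yl on a saturated chain carbon bound to an aromatic carbon. Put simply, 5-methyl-1,3,4-oxadiazol-2-yl stands in place of 1H-1,2,4-triazol-1-yl on a saturated chain carbon bound to an aromatic carbon. Each group is one five-membered aromatic ring.

Going by the values given here, no pair of measured compounds shows what a change like this does, so the expectation is a loose one. It starts from compound 1 at 75900 nM, and no step beyond the scatter is expected in this assay. The expected change is a 1.1-fold lower number from compound 1 to compound 3 (0.04 log units; within the scatter). For compound 3 the estimated value is 70000 nM, with an expected range from 30000 nM to 100000 nM.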

Compound 3, half-maximal effective concentration: 6200 nM
Beside the measured number, compound 3's estimate is 11-fold (1.05 log units) above it, outside the stated range (below it).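

For the compounds shown here, this is the first measured step in this assay, and it shows that the group on this saturated chain carbon bound to an aromatic carbon strongly affects the reading: a 12-fold lower number from compound 1 to compound 3 (1.09 log units; beyond the scatter). Much less compound is needed for the effect with 5-methyl-1,3,4-oxadiazol-2-yl than with 1H-1,2,4-triazol-1-yl, so two five-membered aromatic rings with the same counts of hetero atoms, hydrogen-bond donors and hydrogen-bond acceptors do not behave alike here. The shared core therefore does not fix the result on its own, since changing this one group moves the number beyond the scatter.

On these data alone, this single pair cannot show whether the added methyl, the ring oxygen or the overall ring accounts for the step, and the effect of an amine or a carboxylic acid at this place remains open. Compound 2 has a limit and not a number, so its distance from the other compounds stays unknown, and this caution applies to the assay: the limit of > 100000 nM in this assay, at which 1 of the 3 values shown sits.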